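This account rests on a few compounds, and the source may have more. Where it says the series, first, only, none or still open, it means among the compounds named here.

In a functional assay on A549 cells (Homo sapiens) for inhibition, read by MTT assay, with a stated time of 72 h (a higher number here means a weaker inhibitor, a lower number a stronger inhibitor), compound 1 (`Nc1ccccc1NC(=O)c1ccc(CNC(=O)/C=C/c2cnc3ccccn23)cc1`) gives 832 nM, compound 2 (`Nc1ccccc1NC(=O)c1ccc(CNC(=O)/C=C/c2c[nH]c3ccccc23)cc1`) gives 649 nM and compound 3 (`Nc1ccc(F)cc1NC(=O)c1ccc(CNC(=O)/C=C/c2cnc3cccnn23)cc1`) gives 812 nM, so compound 3 lies within the scatter of both others. Compound 4 (`Nc1ccccc1NC(=O)c1ccc(CNC(=O)/C=C/c2cnc3cccnn23)cc1`) differs from compound 3 by a single change, hydrogen in place of fluoro on an aromatic carbon, turning 2-amino-5-fluorophenyl into 2-aminophenyl: hydrogen in place of fluoro on an aromatic carbon. Within the data shown here, the only measured step, a 1.3-fold lower number from compound 1 to compound 2 (0.11 log units; within the scatter), concerns a different part of the molecule and stays within the scatter. Among the measured compounds shown here, no measured pair tests this fluoro, so the data suggest no direction, and no step beyond the scatter is expected in this assay. The expected change is a 1.0-fold lower number from compound 3 to compound 4 (0.01 log units; within the scatter). Compound 4 is estimated at 800 nM, with an expected range from 350 nM to 1800 nM.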

Compound 4, half-maximal inhibitory concentration: 723 nM
For compound 4 the middle estimate is 1.1-fold (0.04 log units) above the measured one; the range from low to high includes it.
By their numbers in this assay, from the lowest: compounds 2, 4, 3 and 1 (each within the scatter of the next).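

In this assay, hydrogen in place of fluoro, para to an amino group, gives a 1.1-fold lower number from compound 3 to compound 4 (0.05 log units; within the scatter), the first direct test of this position, and the two stay within the scatter. With 2-aminophenyl kept, changing the group on the double-bonded chain carbon gives a 1.1-fold higher number from compound 2 to compound 4 (0.05 log units; within the scatter) and a 1.2-fold lower number from compound 1 to compound 4 (0.06 log units; within the scatter), so these three groups also stay within the scatter. No measured evidence bears on these results. Going by these compounds, whether a chloro or methoxy group at this position would give a step beyond the scatter remains open, as does whether fluoro and hydrogen stay this close alongside the other two chain groups.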